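Trading a Fluorophenyl for Methyl in a Thromboxane Synthase Series

The compounds below may be only part of what the source reports. "The series", "measured", "known", "first", "only" and "open" are said of these compounds alone.

Compound 1, `O=C(O)CCCC/C=C(\c1cccnc1)c1cccc(F)c1`: 55 nM
Compound 2, `CC(C)(CCC/C=C(/c1ccccc1)c1cccnc1)C(=O)O`: 30 nM
Compound 3, `O=C(O)CCCC/C=C(\c1cccnc1)c1cccc([N+](=O)[O-])c1`: 73 nM

All three were tested in an assay (Equus caballus) for inhibition of Thromboxane-A synthase (Homo sapiens), using microsomes; a lower number here means a stronger inhibitor, a higher number a weaker inhibitor. Compound 1 stands second highest of the three numbers; its nearest neighbour is compound 3, the step of a 1.3-fold higher number from compound 1 to compound 3 (0.12 log units; within the scatter), and the gap to compound 2 is also within the scatter, so the three are not distinguishable here.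

Compound 4, `C/C(=C/CCCCC(=O)O)c1cccnc1`, is not yet measured. It differs from compound 1 by methyl in place of 3-fluorophenyl on a double-bonded chain carbon bound to an aromatic carbon and a double-bonded chain carbon. Among the measured compounds shown here, the single step on record, from compound 1 to compound 3, only swaps one substituent on that ring and stays within the scatter; it says nothing about taking the whole ring away. Compound 2 differs from compound 1 in more than one place and gives no guidance either. With no comparable change measured, the expectation for compound 4 in this assay must be wide; the whole aromatic ring is removed, so a weaker result is expected, the step of a 7.3-fold higher number from compound 1 to compound 4 (0.86 log units; beyond the scatter). Compound 4 is estimated at 400 nM, with a range from 60 nM to 3000 nM.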

Compound 4, half-maximal inhibitory concentration: 71 nM
Estimate against measurement, compound 4: 5.6-fold (0.75 log units) above, within the range that was stated.
By their numbers in this assay, from the lowest: compounds 2, 1, 4 and 3 (each within the scatter of the next, the first and the last beyond it).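

In this assay, exchanging the whole ring for the far smaller group gives a 1.3-fold higher number from compound 1 to compound 4 (0.11 log units; within the scatter), with methyl in place of 3-fluorophenyl on a double-bonded chain carbon bound to an aromatic carbon and a double-bonded chain carbon. The earlier step from fluoro to nitro altered only a substituent on that ring, whereas this one shows that, for this pair, the ring itself can go without a readable difference in the number. No supporting data bear on why this ring can be lost so freely.

As far as these compounds go, whether other groups on this carbon, such as a plain hydrogen, an ethyl or a cyclopropyl, would also stay within the scatter remains open. Also open, from the compounds shown here alone, is whether the same exchange would give so small a step on the core of compound 2.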